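This account rests on a few compounds, and the source may have more. Where it says the series, first, only, none or still open, it means among the compounds named here.

Compound 1 `O=C(NC(=S)N1CCc2c(OCCCCCOc3ccc(Cl)cc3)cccc21)c1cccc([N+](=O)[O-])c1` and compound 2 `O=C(CCc1ccccc1)NC(=S)N1CCc2c(OCCCCCOc3ccc(Cl)cc3)cccc21` share one core and differ only in the group on a carbonyl carbon. In an ADME assay on Huh-7 cells (Homo sapiens) for cytotoxicity (on this read-out higher numbers stand for lower toxicity in this test and lower numbers for higher toxicity in this test), compound 1 gives 12100 nM. In this assay compound 2 gives no number but a limit of the test, > 50000 nM; this is the limit of > 50000 nM in this assay, at which 1 of the 2 values shown sits. Among the measured compounds shown here, the step of an at least 4.1-fold higher number from compound 1 to compound 2 (0.61 log units; beyond the scatter) is the only measured step here, and it ends at that limit. Compound 3 `O=C(NC(=S)N1CCc2c(OCCCCCOc3ccc(Cl)cc3)cccc21)c1ccno1` takes the next step from compound 2: 1,2-oxazol-5-yl in place of phenethyl on a carbonyl carbon. For the measured compounds named here, the change brings back an aromatic ring on the carbonyl carbon, as compound 1 carries, though a different one; no measured step covers this change directly, so the expectation leans on the step from compound 1 alone. Compound 3 is therefore expected to land between the two values seen, with an estimated step of an at least 1.6-fold lower number from compound 2 to compound 3 (0.22 log units; that floor lies within the scatter). The estimate for compound 3 is 30000 nM, within a range from 9000 nM to 80000 nM.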

Compound 3, half-maximal cytotoxic concentration: 37100 nM
Compound 3: middle estimate off by 1.2-fold (0.09 log units), on the low side; low and high end bracket the measured number.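

In this assay, replacing 3-nitrophenyl on the carbonyl carbon with 1,2-oxazol-5-yl gives a 3.1-fold higher number from compound 1 to compound 3 (0.49 log units; beyond the scatter), so these two aromatic groups do not read alike here, and an aromatic ring at this position does not by itself bring the lower number seen for compound 1. Against phenethyl, the change gives an at least 1.3-fold lower number from compound 2 to compound 3 (0.12 log units; that floor lies within the scatter), so no real difference between 1,2-oxazol-5-yl and phenethyl can be claimed. The true size of that step stays unknown because compound 2 gives only a limit, not a number: the limit of > 50000 nM in this assay, at which 1 of the 3 values shown sits.

Three compounds cannot tell whether the lower number of compound 1 goes with its nitro group or with its phenyl ring, and a plain phenyl group on the same carbonyl carbon would speak to that. From the compounds shown here alone, how a small alkyl group such as methyl would read at this position also remains open.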